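Iodoacetamide Triphosphate Probes: Linker Extension Toward Hexokinase-3

The source may hold more compounds than are shown below. What is called first, only, known or untested is meant among the compounds shown, and "the series" means these compounds.

In an assay on isolated protein for inhibition of hexokinase-3 (Rattus norvegicus), with a stated time of 6 h, tested at 10 mM (a lower number here means less inhibition, a higher number more inhibition at the concentration tested (going by the name of the read-out)), the three measured compounds gave the following results:

compound 1, `O=C(CI)NCCCNc1ncnc2c1ncn2[C@@H]1O[C@H](COP(=O)(O)OP(=O)(O)OP(=O)(O)O)[C@@H](O)[C@H]1O`: 0%
compound 2, `O=C(CI)NCCCCCC(=O)NCCCNc1ncnc2c1ncn2[C@@H]1O[C@H](COP(=O)(O)OP(=O)(O)OP(=O)(O)O)[C@@H](O)[C@H]1O`: 0%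
compound 3, `O=C(CI)NCCCC(=O)NCCCCCCNc1ncnc2c1ncn2[C@@H]1O[C@H](COP(=O)(O)OP(=O)(O)OP(=O)(O)O)[C@@H](O)[C@H]1O`: 0%

Compound 2 stands level with compound 1 and compound 3 at the digits reported; the nearest of the two is compound 1, the furthest compound 3, and in both cases the gap lies within the scatter. Going by the values given here, the one measured step that reaches compound 2 is no change at the digits printed from compound 1 to compound 2 (within the scatter), which introduces 4-(((iodomethyl)carbonyl)amino)butyl in place of iodo on a saturated chain carbon bound to a carbonyl carbon.

Compound 4, `O=C(CI)NCCCCCCC(=O)NCCCNc1ncnc2c1ncn2[C@@H]1O[C@H](COP(=O)(O)OP(=O)(O)OP(=O)(O)O)[C@@H](O)[C@H]1O`, has not yet been measured. It differs from compound 2 by (((iodomethyl)carbonyl)amino)methyl in place of ((iodomethyl)carbonyl)amino on a saturated chain carbon, five bonds along the chain from a carbonyl carbon; cut one bond further out, the same difference reads 3-(((iodomethyl)carbonyl)amino)propyl to 4-(((iodomethyl)carbonyl)amino)butyl.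

Among the compounds with values here, only the step from compound 1 to compound 2 bears on this change, and it brought no change at the digits reported. Since compounds 1, 2 and 3 all sit at the same read-out, the step for compound 4 is expected to be no change at the digits printed from compound 2 to compound 4 (within the scatter), nothing beyond the scatter in either direction. Compound 4 is therefore estimated at 0%, with a range from 0% to 8%.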

Compound 4, a percentage reported as inhibition, at one concentration (the size of the read-out at that concentration, not a potency): 0%
Estimate against measurement, compound 4: no gap at the digits printed; the measured number falls inside the stated range.
By their numbers in this assay, from the lowest: compounds 1, 2, 3 and 4 (each within the scatter of the next).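

At the saturated chain carbon, five bonds along the chain from a carbonyl carbon, putting (((iodomethyl)carbonyl)amino)methyl in place of ((iodomethyl)carbonyl)amino gives, in this assay, no change at the digits printed from compound 2 to compound 4 (within the scatter), so this further extension of the chain leaves the read-out where it stood. Taken from the shorter end of the series, 5-(((iodomethyl)carbonyl)amino)pentyl in place of iodo on a saturated chain carbon bound to a carbonyl carbon gives no change at the digits printed from compound 1 to compound 4 (within the scatter), which reads the same as the earlier step to the 4-(((iodomethyl)carbonyl)amino)butyl group, no change at the digits printed from compound 1 to compound 2 (within the scatter). The flat reading therefore now extends to one more chain length, and none of the lengths shown brings out any inhibition at the concentration tested.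

The compounds shown leave open whether a longer chain than the 5-(((iodomethyl)carbonyl)amino)pentyl group, or an amine or a carboxylic acid in place of the ((iodomethyl)carbonyl)amino end, would give a reading that differs from these. Nothing available accounts for the unchanged reading across the series.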